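Furan ester to fluorophenyl ester: a low starting point

This account rests on a few compounds, and the source may have more. Where it says the series, first, only, none or still open, it means among the compounds named here.

Compound 1 `Nc1cc(C(F)(F)F)cc2c(=O)cc(N3CCN(CC4CCCCC4)CC3)sc12` and compound 2 `Nc1cc(C(F)(F)F)cc2c(=O)cc(N3CCN(CC4CCC(O)CC4)CC3)sc12` were tested in an ADME assay on cells (Hepatocyte, Mus musculus) for metabolic stability, with a stated time of 30 min; a higher number here means that more of the compound is left, a lower number that less of the compound is left; compound 1 gives 69.4% and compound 2 gives 60%. Between them, a number 9.4 percentage points lower from compound 1 to compound 2 (within the scatter). Compound 3 `O=C(OC1CCC(CN2CCN(c3cc(=O)c4cc(C(F)(F)F)cc([N+](=O)[O-])c4s3)CC2)CC1)c1ccco1` gives 0.6%, the lowest of the three values; compound 2 stands far above it and compound 1 further still, both gaps beyond the scatter. Compound 4 `O=C(OC1CCC(CN2CCN(c3cc(=O)c4cc(C(F)(F)F)cc([N+](=O)[O-])c4s3)CC2)CC1)c1ccc(F)cc1` differs from compound 3 in one place: 4-fluorophenyl in place of furan-2-yl on a carbonyl carbon. No measured step touches the furan-2-yl or the 4-fluorophenyl group, so nothing shown bears directly on this change; the only measured step, hydroxy for hydrogen, stayed within the scatter. Because compound 3 reads 0.6%, the expected step is a number 1.4 percentage points higher from compound 3 to compound 4 (within the scatter), not beyond the scatter. Compound 4 is therefore estimated at 2%, in the range 0% to 15%.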

Compound 4, percent of the compound remaining: 1.5%
Beside the measured number, compound 4's estimate is 0.5 percentage points above it; the measured number falls inside the stated range.
By their numbers in this assay, from the lowest: compounds 3 and 4 (each within the scatter of the next); then compounds 2 and 1 (each within the scatter of the next).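

In this assay, 4-fluorophenyl in place of furan-2-yl on a carbonyl carbon gives a number 0.9 percentage points higher from compound 3 to compound 4 (within the scatter), so this exchange of one aromatic ring for another leaves the number low. At this position, a six-membered ring of carbon only and a five-membered ring with a hetero atom therefore read alike. Nothing shown explains why either compound reads so low.

Still open, from the compounds shown here alone, is whether a pyridine ring at this position would read differently. Also open, going by these compounds, is what a saturated group such as cyclohexyl on the same carbonyl carbon would give.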